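Replacing Phenyl on the Amine Nitrogen of Compound 3

The compounds below may be only part of what the source reports. "The series", "measured", "known", "first", "only" and "open" are said of these compounds alone.

Compound 1 `CC(=O)c1cc(C(=O)N[C@H](C)Cn2ccc(-c3cc(F)c(C#N)c(Cl)c3)n2)n[nH]1`: "not determined" (no result reported)
Compound 2 `CC(=O)c1cccc(NC(=O)C(C)Cn2ccc(-c3ccc(C#N)c(Cl)c3)n2)c1`: 2980 nM
Compound 3 `C[C@@H](Cn1ccc(-c2ccc(C#N)c(Cl)c2)n1)Nc1ccccc1`: > 30000 nM

In a functional assay on VCaP cells (Homo sapiens) for antiproliferative activity, read by CCK-8 assay, with a stated time of 6 days (on this read-out higher numbers stand for weaker inhibition and lower numbers for stronger inhibition), compound 3 gives > 30000 nM, which is a limit of the assay and not a number. Compound 3 thus sits on (the limit of > 30000 nM in this assay, at which 1 of the 3 values shown sits). Compound 4 `C[C@@H](Cn1ccc(-c2ccc(C#N)c(Cl)c2)n1)Nc1nccc(Cl)n1` carries 4-chloropyrimidin-2-yl in place of phenyl on an amine nitrogen. For the measured compounds named here, no measured step covers this change, so the expectation is loose and rests partly on compound 2 with 2980 nM as the only numeric value. A modest shift toward stronger inhibition in this assay is expected, estimated as an at least 2.5-fold lower number from compound 3 to compound 4 (0.39 log units; beyond the scatter). For compound 4 the expected value is 12000 nM, with an estimated range of 3000 nM to 30000 nM.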

Compound 4, half-maximal inhibitory concentration: > 30000 nM
Compound 4 was reported as a limit; the forecaster's own chance of this, stated with the estimate: 40%; middle value at least 2.5-fold (0.39 log units) from the limit.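

For the compounds shown here, compound 3 and compound 4 both stand as limits, not numbers, in this assay, so no step between them can be read. The compounds shown leave open whether 4-chloropyrimidin-2-yl in place of phenyl on an amine nitrogen changes inhibition at all.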